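A few compounds are considered here, and "the series" means these few. Any claim that something is new, unique, unknown or untested is made for them only; others in the source may bear on it.

Of the compounds shown here, two sharing one core have been measured so far. In a functional assay on HepG2 cells (Homo sapiens) for antiproliferative activity, tested at 1 uM (a lower number here means less inhibition, a higher number more inhibition at the concentration tested (going by the name of the read-out)), compound 1 `Cc1ccc(CO/N=C/c2c(C)nn(C)c2Oc2ccc(Cl)cc2)cc1` gives 31.3%, the higher of the two numbers. Compound 2 `Cc1nn(C)c(Oc2ccccc2)c1/C=N/OCc1ccc(C(F)(F)F)cc1` gives 5.8% in this assay, a result that lies well below compound 1 and beyond the usual scatter; these two compounds differ in more than one place, so their numbers alone do not isolate any single change. Compound 3 `COC(=O)c1ccc(CO/N=C/c2c(C)nn(C)c2Oc2ccc(Cl)cc2)cc1` is not yet measured. It differs from compound 1 in one place: methoxycarbonyl in place of methyl on an aromatic carbon. Among the compounds with values here, no measured pair shows what this particular change does. The step of a number 9.3 percentage points lower from compound 1 to compound 3 (within the scatter) that this account means is expected to be small, with an uncertain direction. For compound 3 an inhibition near 22% is expected in this assay. The estimated range for compound 3 runs from 3% to 45%.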

Compound 3, a percentage reported as inhibition, at one concentration (the size of the read-out at that concentration, not a potency): 20.3%
Estimate against measurement, compound 3: 1.7 percentage points above, and the stated range covers the measured number.
By their numbers in this assay, from the lowest: compound 2; then compound 3; then compound 1.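

Within the data shown here, the exchange of methyl for methoxycarbonyl, on an aromatic carbon para to a large group, gives the first step in this assay that isolates a single change: a number 11 percentage points lower from compound 1 to compound 3 (beyond the scatter), and this step is modest. Inhibition at this position therefore responds to the substituent but is not lost with the larger group, as compound 3 still gives 20.3% at the concentration tested. No measurement available here bears on what lies behind this step.

The compounds shown leave open whether a similar step would follow from other groups on this carbon, such as a carboxylic acid, an amine or a longer alkyl chain. Among these compounds, they also leave open whether the same exchange would give a step of similar size in a compound without the chlorine, since this is the only pair that isolates it.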